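The source may hold more compounds than are shown below. What is called first, only, known or untested is meant among the compounds shown, and "the series" means these compounds.

Measured so far in a functional assay on UO-31 cells (Homo sapiens) for inhibition, read by sulforhodamine B assay, with a stated time of 48 h, tested at 10 uM; on this read-out lower numbers stand for a stronger effect and higher numbers for a weaker effect at the one concentration tested:
- compound 1, `O=C(Nc1cccc(-n2cc(-c3ccncc3)c(-c3cc(O)cc(Cl)c3)n2)c1)Nc1ccc(Cl)c(C(F)(F)F)c1`: 18.5%
- compound 2, `O=C(Nc1cccc(-n2cc(-c3ccncc3)c(-c3cc(O)cc(Cl)c3)n2)c1)Nc1ccc(Cl)c(Cl)c1`: -41.3%
- compound 3, `COc1cc(Cl)cc(-c2nn(-c3cccc(NC(=O)Nc4cc(C(F)(F)F)cc(C(F)(F)F)c4)c3)cc2-c2ccncc2)c1`: -0.18%

For the measured compounds named here, compound 2 gives the lowest number of the three, beyond the scatter from both compound 1 and compound 3, the one measured step being a number 59.8 percentage points lower from compound 1 to compound 2 (beyond the scatter). Compound 4, `COc1cc(Cl)cc(-c2nn(-c3cccc(NC(=O)Nc4ccc(Cl)c(Cl)c4)c3)cc2-c2ccncc2)c1`, is not yet measured. It differs from compound 2 by methyl in place of hydrogen on an oxygen on an aromatic ring. Going by the values given here, no measured step covers this change; compound 1 and compound 3 differ in more than one place, and their values simply show compound 3 somewhat lower than compound 1. With nothing bearing directly on the change, the expected step of a number 11.3 percentage points higher from compound 2 to compound 4 (beyond the scatter) is of uncertain size and direction, most likely modest. Compound 4 is therefore estimated at -30%, in the range -60% to 5%.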

Compound 4, a percentage reported as activity, at one concentration (the size of the read-out at that concentration, not a potency): 0.64%
Compound 4: middle estimate off by 30.6 percentage points, on the low side; the measured number falls inside the stated range.
By their numbers in this assay, from the lowest: compound 2; then compounds 3 and 4 (each within the scatter of the next); then compound 1.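

In this assay, hydroxy to methoxy on the 3-chloro-5-hydroxyphenyl group is far from a neutral change: a number 41.9 percentage points higher from compound 2 to compound 4 (beyond the scatter). For the compounds shown here, this is the first measured step at this oxygen, and it is large, so the read-out depends strongly on whether hydrogen or methyl sits there. Nothing available explains this step.

Open, as far as these compounds go, is how an amine or a longer chain such as ethoxy would read at this place. Also open, from the compounds shown here alone, is whether a step of this size holds when the other end of the molecule changes.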